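Hydroxycyclohexyl in place of a spiroketal on the shared core

This account rests on a few compounds, and the source may have more. Where it says the series, first, only, none or still open, it means among the compounds named here.

Compound 1 `O=C(Nc1ccccc1)Nc1ccc(-c2nc(N3CC4CCC(C3)O4)c3cnn(C4CCC5(CC4)OCCO5)c3n2)cc1` and compound 2 `CNC(=O)Nc1ccc(-c2nc(N3CC4CCC(C3)O4)c3cnn(C4CCC5(CC4)OCCCO5)c3n2)cc1` share one core and differ in more than one place, so only their two values are shown side by side. In an in vitro ADME assay on microsomes (Homo sapiens) for metabolic stability (a higher number here means that the compound lasts longer, a lower number that the compound disappears faster), compound 1 gives 0.217 h. For compound 2 the result in this assay is a limit, > 0.5 h, and not a number; this is the limit of > 0.5 h in this assay, at which 1 of the 2 values shown sits. Compound 3 `CNC(=O)Nc1ccc(-c2nc(N3CC4CCC(C3)O4)c3cnn([C@H]4CC[C@H](O)CC4)c3n2)cc1` is the unmeasured partner of compound 2, and the change between them is a group of 7 heavy atoms (6 carbon, 1 oxygen; one six-membered non-aromatic ring of carbon only) in place of a group of 11 heavy atoms (9 carbon, 2 oxygen; one six-membered non-aromatic ring of carbon only, one six-membered non-aromatic ring with 2 hetero atoms), on an aromatic nitrogen. Among the compounds with values here, no measured step of this kind is available, so the size of the step cannot be read from the data. The expectation for compound 3 in this assay is a step that the limit leaves unreadable from compound 2 to compound 3, that is none beyond the usual scatter. Compound 3 is therefore estimated at 0.6 h, with a range from 0.3 h to 1.2 h, and a fair chance that only a limit is reported again.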

Compound 3, half-life: > 0.5 h
Compound 3: only a limit was reported (the forecaster's own chance of this, stated with the estimate: 55%); the middle value is on the limit's open side.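

Within the data shown here, compound 2 and compound 3 both stand at a limit and not at a number in this assay, so no step between them can be read. On these data alone, how far the half-life of either compound lies past that limit, and whether 4-hydroxycyclohexyl shifts it, stays open.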